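The compounds below may be only part of what the source reports. "The series", "measured", "known", "first", "only" and "open" are said of these compounds alone.

Measured compounds:
compound 1 `COc1cc2nc(-c3ccccc3Cl)nc(N=[N+]=[N-])c2cc1OC`, 8000 nM
compound 2 `COc1cc2nc(-c3cccc(C)c3)nc(N=[N+]=[N-])c2cc1OC`, 9000 nM

Both compounds were tested in a functional assay on HCT-116 cells (Homo sapiens) for cytotoxicity, read by MTT assay, with a stated time of 72 h; a higher number here means a weaker inhibitor, a lower number a stronger inhibitor. Compound 1 gives 8000 nM, and compound 2 gives 9000 nM, so compound 1 stands alongside compound 2, the two numbers lying within the usual scatter of each other; no order between them can be read from the data.

Compound 3 `COc1cc2nc(-c3ccc(C)cc3)nc(N=[N+]=[N-])c2cc1OC` has not been measured. It differs from compound 1 in one place: 4-methylphenyl in place of 2-chlorophenyl on an aromatic carbon. For the measured compounds named here, the one measured step that bears on this is a 1.1-fold higher number from compound 1 to compound 2 (0.05 log units; within the scatter), where a methylphenyl group also took the place of the 2-chlorophenyl group, and the number stayed within the scatter. On that basis the step of a 1.1-fold higher number from compound 1 to compound 3 (0.05 log units; within the scatter) is expected to stay within the scatter as well, with no direction beyond it. Compound 3 is therefore estimated to give 9000 nM in this assay, with a range from 4000 nM to 20000 nM.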

Compound 3, half-maximal inhibitory concentration: 8000 nM
Beside the measured number, compound 3's estimate is 1.1-fold (0.05 log units) above it, within the range that was stated.
By their numbers in this assay, from the lowest: compounds 1, 3 and 2 (each within the scatter of the next).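

Putting 4-methylphenyl in place of 2-chlorophenyl on this aromatic carbon gives no change at the digits printed from compound 1 to compound 3 (within the scatter) in this assay, and putting it in place of 3-methylphenyl gives a 1.1-fold lower number from compound 2 to compound 3 (0.05 log units; within the scatter) in the same test. For the compounds shown here, the earlier pair covered only one methylphenyl group, but now 2-chlorophenyl, 3-methylphenyl and 4-methylphenyl cannot be told apart by this assay on this shared core. Nothing measured alongside these numbers speaks to why the three values sit together.

As far as these compounds go, each of the three groups is a phenyl ring carrying a single chlorine or a single methyl, so it remains open whether an amine, a carboxylic acid or a longer alkyl chain on that ring would move the number beyond the scatter. Also open, from the compounds shown here alone, is whether a pyridine ring in place of the phenyl ring would do so.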